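A few compounds are considered here, and "the series" means these few. Any claim that something is new, unique, unknown or untested is made for them only; others in the source may bear on it.

Measured so far in an ADME assay on HEK293 cells (Homo sapiens) for cytotoxicity, read by CellTiter-Glo and resazurin assay, with a stated time of 72 h; a lower number here means that less compound is needed, a higher number that more compound is needed for the effect:

Compound 1 `CCOC(=O)CCCCCOc1cccc(CN(C(=O)c2ccccc2)C(C)C)c1` gives > 26000 nM, which is a limit of this assay.
Compound 2 `CCOC(=O)CCCCCOc1cccc(CN(C(=O)c2ccc(-c3cccc(NC(C)=O)c3)cc2)C(C)C)c1` gives > 26000 nM, which is a limit of this assay.
Compound 3 `CCOC(=O)CCCCCOc1cccc(CN(C(=O)c2ccc(-c3ccoc3)cc2)C(C)C)c1` gives > 26000 nM, which is a limit of this assay.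

Compound 1 therefore stands nowhere on a scale of numbers: it sits at the limit, and so do the other two compounds (the limit of > 26000 nM in this assay, at which 3 of the 3 values shown sit). The three measured steps all change a hydrogen on an aromatic carbon of the benzoyl ring, and none of them can be read: a step that the two limits leave unreadable from compound 1 to compound 2, a step that the two limits leave unreadable from compound 1 to compound 3, a step that the two limits leave unreadable from compound 2 to compound 3.

Compound 4 `CCOC(=O)CCCCCOc1cccc(CNC(C)C)c1` differs from compound 1 in another place: hydrogen in place of benzoyl on an amine nitrogen. Among the compounds with values here, no measured step touches the amine nitrogen, so nothing measured bears directly on this change. Within the data shown here, what the series shows is only that three compounds with the shared core, carrying a benzoyl or an extended benzoyl on that nitrogen, all fail to reach a readable effect in this assay.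

Against that background compound 4 is expected to behave alike, most likely returning a limit again rather than a number. The step from compound 1 to compound 4 is expected as a step that the limit leaves unreadable from compound 1 to compound 4, that is, none that can be read. Compound 4 is estimated at 30000 nM, with a range from 10000 nM to 100000 nM.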

Compound 4, half-maximal effective concentration: > 26000 nM
Compound 4: no number, only a limit; the forecaster's own chance of this, stated with the estimate: 80%; the middle value lies beyond the limit too.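

Compound 4 gives > 26000 nM in this assay, which is a limit and not a number. With compound 1 also at a limit, no new step can be read between compound 1 and compound 4: the limit of > 26000 nM in this assay, at which 4 of the 4 values shown sit.

The compounds shown leave open whether any change on the shared core gives a readable value in this assay.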